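Tert-butyl ester series: pyridinyl isomer step

A few compounds are considered here, and "the series" means these few. Any claim that something is new, unique, unknown or untested is made for them only; others in the source may bear on it.

Compound 3 `CC1=NC(C)=C([N+](=O)[O-])C(c2ccccn2)/C1=C(\O)OC(C)(C)C` is the weakest of the three measured compounds in a functional assay (cardiac atrium) for agonist activity, with Cavia porcellus as the target (on this read-out lower numbers stand for an effect already at smaller amounts and higher numbers for an effect only at larger amounts of compound), where compound 3 gives 1810000 nM. Compound 1 `CC1=NC(C)=C([N+](=O)[O-])C(c2ccccn2)/C1=C(\O)OC1CCCC1` gives 19800 nM and compound 2 `CC1=NC(C)=C([N+](=O)[O-])C(c2cccnc2)/C1=C(\O)OC(C)C` gives 28500 nM; both stand well below compound 3, with compound 2 the nearer of the two. Among the measured compounds shown here, the only single-point step among the measured compounds concerns the ester: a 91-fold higher number from compound 1 to compound 3 (1.96 log units; beyond the scatter), which places the tert-butyl ester at the weak end of the series.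

Compound 4 `CC1=NC(C)=C([N+](=O)[O-])C(c2cccnc2)/C1=C(\O)OC(C)(C)C` is unmeasured. It is related to compound 3 by pyridin-3-yl in place of pyridin-2-yl on a saturated ring carbon, the tert-butyl ester being kept. For the measured compounds named here, no measured pair isolates this change: compound 1 and compound 2 differ in the pyridinyl group but also in the ester, so their two values give no clean reading of the isomer alone. The ester step does not bear on the pyridinyl isomer. For compound 4 a step of a 1.2-fold lower number from compound 3 to compound 4 (0.08 log units; within the scatter) is therefore expected, no more than a modest move in either direction, with the number remaining high as it is for compound 3. Compound 4 is estimated at 1500000 nM, with a range from 300000 nM to 7000000 nM.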

Compound 4, half-maximal effective concentration: 14600 nM
The estimate for compound 4 lay 100-fold (2.01 log units) above the measured number; the whole stated range lies above it.
By their numbers in this assay, from the lowest: compounds 4, 1 and 2 (each within the scatter of the next); then compound 3.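

In this assay, the pyridinyl isomer turns out to be a decisive change on this saturated ring carbon: with the tert-butyl ester kept and the same atoms merely joined differently, the step is a 120-fold lower number from compound 3 to compound 4 (2.09 log units; beyond the scatter) and is large. With pyridin-3-yl kept, methyl in place of hydrogen on the ester chain carbon gives a 2.0-fold lower number from compound 2 to compound 4 (0.29 log units; within the scatter), so this ester change does not register in that pair. The weak number of compound 3 therefore belongs to the combination of tert-butyl ester and pyridin-2-yl, not to the tert-butyl ester alone, and nothing available accounts for the size of the isomer step.

Whether the isomer step holds with the cyclopentyl ester of compound 1 or the ester of compound 2 stays open, as the only clean isomer pair shown carries the tert-butyl ester. As far as these compounds go, how pyridin-4-yl or an unsubstituted phenyl ring would read at this position on the shared core also remains open.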